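Methoxy in place of methyl: compound 3 in prospect

The source may report more compounds than this note shows. Statements on the series, on what has been measured and on what is new or still open speak of the compounds shown alone.

Measured in an ADME assay (liver) for metabolic stability, with Liver microsome (Rattus norvegicus) as the target, using microsomes and NADPH, with a stated time of 30 min, tested at 1 uM; a higher number here means faster removal of the compound, a lower number slower removal:
compound 1 `Cc1csc(-c2cc(C(O)(C(F)(F)F)C(F)(F)F)cnc2N2CCN(S(=O)(=O)c3ccc(N)nc3)CC2)c1`: 399 mL.min-1.g-1
compound 2 `Cc1ccc(-c2cc(C(O)(C(F)(F)F)C(F)(F)F)cnc2N2CCN(S(=O)(=O)c3ccc(N)nc3)CC2)cn1`: 182 mL.min-1.g-1

Of the two measured compounds, compound 2 stands lowest, at 182 mL.min-1.g-1. Compound 3 `COc1ccc(-c2cc(C(O)(C(F)(F)F)C(F)(F)F)cnc2N2CCN(S(=O)(=O)c3ccc(N)nc3)CC2)cn1` differs from it in one place: methoxy in place of methyl on an aromatic carbon. This puts methoxy in place of methyl on an aromatic carbon, next to the ring nitrogen, so that 6-methylpyridin-3-yl becomes 6-methoxypyridin-3-yl.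

For the measured compounds named here, only one measured step bears on this, and only indirectly: a 2.2-fold lower number from compound 1 to compound 2 (0.34 log units; beyond the scatter), a modest step that exchanged 4-methylthiophen-2-yl for 6-methylpyridin-3-yl. Going by the values given here, no measured pair compares methoxy with methyl, so the direction remains open, and no change beyond the scatter is expected. The expected step is a 1.1-fold higher number from compound 2 to compound 3 (0.04 log units; within the scatter). For compound 3, the estimated value in this assay is 200 mL.min-1.g-1, with an expected range of 95 mL.min-1.g-1 to 420 mL.min-1.g-1.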

Compound 3, intrinsic clearance in microsomes: 265 mL.min-1.g-1
Estimate against measurement, compound 3: 1.3-fold (0.12 log units) below; low and high end bracket the measured number.
By their numbers in this assay, from the lowest: compounds 2, 3 and 1 (each within the scatter of the next, the first and the last beyond it).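

At this carbon next to the ring nitrogen, this assay does not separate methoxy from methyl: the step is a 1.5-fold higher number from compound 2 to compound 3 (0.16 log units; within the scatter). Nor does it separate 6-methoxypyridin-3-yl from 4-methylthiophen-2-yl, with a 1.5-fold lower number from compound 1 to compound 3 (0.18 log units; within the scatter), so compound 3 lies within the scatter of both other compounds, although a 2.2-fold lower number from compound 1 to compound 2 (0.34 log units; beyond the scatter) remains a step beyond it. No measurement offered here gives a reason for this reading.

The compounds shown leave open whether an amine such as dimethylamino, or a longer chain such as ethoxy, on this same carbon would give a step beyond the scatter from compound 2. They also leave open whether methoxy would read the same on a thiophene ring as it does here.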